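A Benzyl Swap Carried From One Core to Another

The compounds below may be only part of what the source reports. "The series", "measured", "known", "first", "only" and "open" are said of these compounds alone.

Compound 1 `O=C1O/C(=C\Cn2cc(Cc3ccccc3)nn2)C(OCc2ccccc2)=C1OCc1ccccc1` gives 40000 nM in a functional assay on MCF7 cells (Homo sapiens) for antiproliferative activity, read by MTT assay, with a stated time of 24 h; a lower number here means a stronger inhibitor, a higher number a weaker inhibitor. For compound 2 `CC(C)(C)c1ccc(-c2cn(C/C=C3\OC(=O)C(OCc4ccccc4)=C3OCc3ccccc3)nn2)cc1` the result in this assay is > 100000 nM, which is a limit rather than a number, namely (the limit of > 100000 nM in this assay, at which 1 of the 3 values shown sits). Going from compound 2 to compound 1 puts (benzyl in place of 4-(tert-butyl)phenyl on an aromatic carbon), and that change gives an at least 2.5-fold lower number from compound 2 to compound 1 (0.39 log units; beyond the scatter).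

Compound 3 `CC(C)(C)c1ccc(-c2cn(CCC3(O)NC(=O)C(OCc4ccccc4)=C3OCc3ccccc3)nn2)cc1` gives 25100 nM in this assay; set against compound 1 the two numbers lie within the usual scatter of each other. Compound 3 and compound 2 rest on different cores, and the difference between the two cores is not broken down here.

Compound 4 `O=C1NC(O)(CCn2cc(Cc3ccccc3)nn2)C(OCc2ccccc2)=C1OCc1ccccc1` is not yet measured. From compound 3 it carries the same change, (benzyl in place of 4-(tert-butyl)phenyl on an aromatic carbon), at a place described in the same words as before. Compound 4 is expected to show a 2.5-fold lower number from compound 3 to compound 4 (0.40 log units; beyond the scatter), because the same change gave an at least 2.5-fold lower number from compound 2 to compound 1 (0.39 log units; beyond the scatter). For compound 4 the expected value in this assay is therefore 10000 nM, with 4000 nM and 30000 nM as the likely bounds.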

Compound 4, half-maximal inhibitory concentration: 39200 nM
The estimate for compound 4 lay 3.9-fold (0.59 log units) below the measured number, and the stated range ends below it.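

In this assay, putting benzyl in place of 4-(tert-butyl)phenyl on the core of compound 3 gives a 1.6-fold higher number from compound 3 to compound 4 (0.19 log units; within the scatter), so on this core the swap has no effect that can be read. The result of the swap therefore did not carry from one core to the other, as the two steps differ: the same change on two cores in this assay, an at least 2.5-fold lower number (0.39 log units; beyond the scatter) from compound 2 to compound 1 and a 1.6-fold higher number (0.19 log units; within the scatter) from compound 3 to compound 4, at least 3.9-fold (0.59 log units) apart, beyond the scatter of two such steps

Within the data shown here, with only one pair on each core, this shows that the same swap can end differently on these two cores, but it does not show which part of the cores is responsible, nor how the swap would behave on any further core.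

On these data alone, compound 2 gives > 100000 nM, which is a limit of the assay and not a number, so the true size of the earlier step stays open. Also open, as far as these compounds go, is how a longer chain in place of benzyl, or an amine or a carboxylic acid on its ring, would fare on each of the two cores.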